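Moving one methyl group on compound 3

The source may report more compounds than this note shows. Statements on the series, on what has been measured and on what is new or still open speak of the compounds shown alone.

Compound 1 `CCCCCCNC(=S)N/N=C1\C(=O)Nc2ccc([N+](=O)[O-])cc21` gives 60% here
Compound 2 `C=CCNC(=S)N/N=C1\C(=O)Nc2ccc([N+](=O)[O-])cc21` gives 50% here
Compound 3 `Cc1cccc(NC(=S)N/N=C2\C(=O)Nc3ccc([N+](=O)[O-])cc32)c1` gives 25% here

All three values come from a functional assay on the whole organism for inhibition, with Lemna aequinoctialis as the target, tested at 1000 ug/mL (a lower number here means less inhibition of growth, a higher number more inhibition of growth at the concentration tested), and the three compounds share one core. Compound 3 stands lowest of the three, and both of the others lie above it beyond the scatter.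

Compound 4 `Cc1ccc(NC(=S)N/N=C2\C(=O)Nc3ccc([N+](=O)[O-])cc32)cc1` differs from compound 3 in one place 4-methylphenyl in place of 3-methylphenyl on an amide-type nitrogen and has the same atoms joined differently: 4-methylphenyl in place of 3-methylphenyl on an amide-type nitrogen.

Going by the values given here, no measured step moves the methyl group, so the evidence is indirect. Putting 3-methylphenyl in place of allyl gave a number 25 percentage points lower from compound 2 to compound 3 (beyond the scatter) and putting it in place of hexyl gave a number 35 percentage points lower from compound 1 to compound 3 (beyond the scatter), but both of these swap a whole group, while here a methylphenyl stays. A step within the scatter is therefore expected, with no firm direction.

The estimated change is a number 5 percentage points higher from compound 3 to compound 4 (within the scatter) in this measurement. For compound 4 the expected value is 30%, with an estimated range from 15% to 45% as its likely span.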

Compound 4, percent growth inhibition at one concentration: 30%
The estimate for compound 4 equals the measured number at the digits printed, and the stated range covers the measured number.
By their numbers in this assay, from the lowest: compounds 3 and 4 (each within the scatter of the next); then compounds 2 and 1 (each within the scatter of the next).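

In this assay there is a number 5 percentage points higher from compound 3 to compound 4 (within the scatter) when the methyl group moves, so on this amide-type nitrogen the change from 3-methylphenyl to 4-methylphenyl has no readable effect. The second methylphenyl compound also repeats the gap to the chain compounds seen with compound 3, with a number 20 percentage points lower from compound 2 to compound 4 (beyond the scatter) and a number 30 percentage points lower from compound 1 to compound 4 (beyond the scatter) in the same assay, and so all four compounds split into a chain pair and a methylphenyl pair. Nothing measured here explains either the gap or the lack of a methyl effect.

Going by these compounds, what a plain phenyl or a 4-chlorophenyl group would give on this nitrogen remains open. So does whether a chain longer than hexyl would hold, raise or lower the number in this assay.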